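A few compounds are considered here, and "the series" means these few. Any claim that something is new, unique, unknown or untested is made for them only; others in the source may bear on it.

Compound 1, `COCCNC(=O)c1cc2cccc(OC)c2oc1=N`, is the starting point of this account. For the measured compounds named here, in an assay on HEK293 cells for displacement of a labelled ligand from adenosine receptor A2b (Homo sapiens), read by scintillation counting, with a stated time of 30 min, tested at 10 uM (a lower number here means less inhibition, a higher number more inhibition at the concentration tested (going by the name of the read-out)), compound 1 gives 43%, the highest of the three numbers measured so far. Its nearest neighbour on the numbers is compound 3, `O=C(NCC(O)CO)c1cc2cccc(O)c2oc1=O`, which in this assay gives 29%, a gap beyond the usual scatter. Furthest away lies compound 2, `N=c1oc2ccc(Br)cc2cc1C(=O)NC1CCCCC1`, which in this assay gives 10%, also beyond the scatter. The three compounds share a core but differ from one another in more than one place, so none of these gaps can be tied to a single structural change.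

Compound 4, `COc1cccc2cc(C(=O)NCCCCCO)c(=N)oc12`, has not yet been measured. It differs from compound 1 in one place: 3-hydroxypropyl in place of methoxy on a saturated chain carbon, two bonds along the chain from an amide-type nitrogen. Going by the values given here, no measured pair shows this change on its own, so its effect has to be guessed from the general level of compound 1. The step expected here in this assay is a small one, most likely none beyond the scatter, with a slight lean toward a lower number; this expectation means a step of a number 5 percentage points lower from compound 1 to compound 4 (within the scatter). Compound 4 is therefore expected to give about 38%, within a range from 20% to 56%.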

Compound 4, a percentage reported as inhibition, at one concentration (the size of the read-out at that concentration, not a potency): > 70%
Compound 4 was reported as a limit (the forecaster's own chance of this, stated with the estimate: 0%); at least 32 percentage points between middle value and limit.
By their numbers in this assay, from the lowest: compound 2; then compound 3; then compound 1. At a limit, above all of these: compound 4.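

For the compounds shown here, replacing methoxy with 3-hydroxypropyl on a saturated chain carbon, two bonds along the chain from an amide-type nitrogen, is the first change in these compounds that can be read on its own, and it gives a number at least 27 percentage points higher from compound 1 to compound 4 (beyond the scatter). In this assay compound 4 gives > 70%, which is a limit of the assay and not a number. Going by these compounds alone, the side chain on the amide nitrogen is therefore a place where a single change moves this read-out well beyond the scatter, something the earlier compounds, which differ in more than one place, could not show, and the step is fixed from one side only: the limit of > 70% in this assay, at which 1 of the 4 values shown sits.

The change adds chain length and a hydrogen-bond donor at once, so the compounds shown do not tell these two apart, and a plain pentyl chain or a 5-methoxypentyl chain on the same amide would be needed to separate them. They also leave open whether the hydroxyl could give way to an amine or a carboxylic acid at the chain end, and how a longer chain, such as 6-hydroxyhexyl, would read.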